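Swapping Trifluoromethyl for Nitro: What Compound 4 May Tolerate

A few compounds are considered here, and "the series" means these few. Any claim that something is new, unique, unknown or untested is made for them only; others in the source may bear on it.

Compound 1 `O=c1[nH]c(Nc2cc(F)cc(F)c2)nc2cc(C(F)(F)F)ccc12`, compound 2 `O=c1[nH]c(Nc2cc(F)cc(F)c2)nc2cc([N+](=O)[O-])ccc12` and compound 3 `O=c1[nH]c(Nc2cc(Cl)cc(Cl)c2)nc2cc(C(F)(F)F)ccc12` share a core and were tested in an ADME assay on Vero cells (Chlorocebus sabaeus) for cytotoxicity, read by WST assay; a lower number here means that less compound is tolerated, a higher number that more compound is tolerated. Compound 1 gives only a limit of the assay, >= 7600 nM. Compound 2 also gives only a limit, > 25000 nM. Compound 3 gives 7100 nM. Compound 3 differs from compound 1 by 3,5-dichlorophenyl in place of 3,5-difluorophenyl on a nitrogen on an aromatic ring, and that step is an at least 1.0-fold lower number from compound 1 to compound 3 (0.02 log units; that floor lies within the scatter). Compound 2 differs from compound 1 by nitro in place of trifluoromethyl on an aromatic carbon; that step is a step that the two limits leave unreadable from compound 1 to compound 2 because the limit of > 25000 nM in this assay, at which 1 of the 3 values shown sits, and the limit of >= 7600 nM in this assay, at which 1 of the 3 values shown sits, bound it on both sides.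

Compound 4 `O=c1[nH]c(Nc2cc(Cl)cc(Cl)c2)nc2cc([N+](=O)[O-])ccc12` has not been measured; it differs from compound 3 by nitro in place of trifluoromethyl on an aromatic carbon, the same change as from compound 1 to compound 2. Beside that unreadable step, the step from compound 3 to compound 4 in this assay is expected to be a 1.4-fold higher number from compound 3 to compound 4 (0.15 log units; within the scatter), an expectation resting on the step that the two limits leave unreadable from compound 1 to compound 2, which does not point downward. Compound 4 is therefore estimated at 10000 nM, with a likely range from 4000 nM to 30000 nM.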

Compound 4, half-maximal cytotoxic concentration: > 25000 nM
Compound 4: no number, only a limit; the forecaster's own chance of this, stated with the estimate: 40%; middle value at least 2.5-fold (0.39 log units) away from the limit.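

In this assay nitro in place of trifluoromethyl on an aromatic carbon brings an at least 3.5-fold higher number from compound 3 to compound 4 (0.54 log units; beyond the scatter) with 3,5-dichlorophenyl on the nitrogen. As far as these compounds go, compound 4 gives only a limit of the assay (> 25000 nM) and so the full size of this step stays unknown. With 3,5-difluorophenyl on the nitrogen the same change cannot be read, so the step is neither confirmed nor contradicted on a second core, because both of its ends are limits: the limit of > 25000 nM in this assay, at which 2 of the 4 values shown sit, and (the limit of >= 7600 nM in this assay, at which 1 of the 4 values shown sits).

The compounds shown leave open whether the higher number is particular to nitro. An amine or a carboxylic acid on the same aromatic carbon could help to test this.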